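The compounds below may be only part of what the source reports. "The series", "measured", "known", "first", "only" and "open" are said of these compounds alone.

Measured so far in a functional assay on U-937 cells (Homo sapiens) for antiproliferative activity, read by MTT assay, with a stated time of 24 h; a lower number here means a stronger inhibitor, a higher number a weaker inhibitor:
- compound 1 `CCCCc1oc2ccccc2c1C(=O)c1ccc(OCC(=O)Nc2ccccc2)cc1` gives 25900 nM
- compound 2 `CCCCc1oc2ccccc2c1C(=O)c1ccc(OCC(=O)Nc2cccc(OC)c2)cc1` gives 24200 nM
- compound 3 `CCCCc1oc2ccccc2c1C(=O)c1ccc(OCC(=O)NCc2ccccc2)cc1` gives 16300 nM

Compound 3 cannot be separated from the other two compounds. The measured steps that end at it, a 1.6-fold lower number from compound 1 to compound 3 (0.20 log units; within the scatter) and a 1.5-fold lower number from compound 2 to compound 3 (0.17 log units; within the scatter), are small enough to count as repeat-to-repeat scatter.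

The next compound is compound 4 `CCCCc1oc2ccccc2c1C(=O)c1ccc(OCCCC(=O)N2CCCCC2)cc1`, which has 2-((piperidin-1-yl)carbonyl)ethyl in place of benzylcarbamoyl on a saturated chain carbon bound to an oxygen on an aromatic ring. The counted difference is 2-((piperidin-1-yl)carbonyl)ethyl in place of benzylcarbamoyl on a saturated chain carbon bound to an oxygen on an aromatic ring. Read one bond further out, (benzylcarbamoyl)methyl becomes 3-((piperidin-1-yl)carbonyl)propyl, and a six-membered non-aromatic ring replaces the six-membered aromatic ring of carbon only.

The two steps above bear most closely on this change, since both alter the group on the amide-type nitrogen. The step of a 1.1-fold lower number from compound 1 to compound 2 (0.03 log units; within the scatter), made on an aromatic carbon, is also small. Going by the values given here, no measured compound carries the new group, so the evidence is indirect and the range must stay wide. With no measured step beyond the scatter, the expected step is a 1.2-fold higher number from compound 3 to compound 4 (0.09 log units; within the scatter), which means no real change is expected in this assay. For compound 4 the estimate is 20000 nM, with an expected range from 8000 nM to 50000 nM.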

Compound 4, half-maximal inhibitory concentration: 16600 nM
Compound 4: the middle estimate sits 1.2-fold (0.08 log units) above what was measured; the range from low to high includes it.
By their numbers in this assay, from the lowest: compounds 3, 4, 2 and 1 (each within the scatter of the next).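

In this assay, going by these compounds alone, this position tolerates a far larger rewrite than the earlier compounds showed: the step of a 1.0-fold higher number from compound 3 to compound 4 (0.01 log units; within the scatter) replaces benzylcarbamoyl with 2-((piperidin-1-yl)carbonyl)ethyl, and the comparisons with the two anilide-type compounds, a 1.5-fold lower number from compound 2 to compound 4 (0.16 log units; within the scatter) and a 1.6-fold lower number from compound 1 to compound 4 (0.19 log units; within the scatter), tell the same story. Until now only the group on the amide-type nitrogen had varied, whereas here the six-membered aromatic ring of carbon gives way to a six-membered non-aromatic ring with one hetero atom, the amide hydrogen is lost, and (benzylcarbamoyl)methyl becomes 3-((piperidin-1-yl)carbonyl)propyl, all without a step beyond the scatter. No measurement among the data shown accounts for this flat result.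

The ring, the amide hydrogen and the chain all differ at once in this step, so the compounds shown leave open what each of these changes would do alone. Also open, going by these compounds, is whether a different kind of group on this chain, such as a carboxylic acid or an amine without the carbonyl, would give a step beyond the scatter.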